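Isopropylcarbonyl for methyl on compound 1

A few compounds are considered here, and "the series" means these few. Any claim that something is new, unique, unknown or untested is made for them only; others in the source may bear on it.

Going by the values given here, in a functional assay on A549 cells (Homo sapiens) for cytotoxicity, read by MTT assay, with a stated time of 72 h (on this read-out higher numbers stand for weaker inhibition and lower numbers for stronger inhibition), compound 1 `COc1cc(/C=C2\CN(C)C/C(=C\c3cc(OC)c(OC)c(OC)c3)C2=O)cc(OC)c1OC` gives 1700 nM and holds the lower of the two numbers known so far. Compound 2 `CCN1C/C(=C\c2ccc(OC)c(OC)c2)C(=O)/C(=C/c2ccc(OC)c(OC)c2)C1` gives 3600 nM in the same read-out, a gap beyond the usual scatter, though the two compounds differ in more than one place. Compound 3 `COc1cc(/C=C2\CN(C(=O)C(C)C)C/C(=C\c3cc(OC)c(OC)c(OC)c3)C2=O)cc(OC)c1OC` keeps the core of compound 1 but carries isopropylcarbonyl in place of methyl on an amine nitrogen in a ring. Among the compounds with values here, no measured pair isolates this change, so its direction remains a matter of judgement. A modest shift toward stronger inhibition in this assay is expected, and a result within the scatter would be no surprise. The expected change is a 2.1-fold lower number from compound 1 to compound 3 (0.33 log units; beyond the scatter) in this estimate. For compound 3 the estimated value is 800 nM with a likely range from 200 nM to 3000 nM in this read-out.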

Compound 3, half-maximal inhibitory concentration: 800 nM
Compound 3: middle estimate and measured number agree at the digits printed, and the stated range covers the measured number.
By their numbers in this assay, from the lowest: compound 3; then compound 1; then compound 2.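

Going by these compounds alone, until now no measured pair isolated a change on the amine nitrogen in a ring. In this assay the replacement of methyl by isopropylcarbonyl gives a 2.1-fold lower number from compound 1 to compound 3 (0.33 log units; beyond the scatter), so stronger inhibition is seen at this position with the larger group. The change brings 5 heavy atoms in place of 1 and adds a hydrogen-bond acceptor, yet the data show only the net step and no information on what lies behind it.

Going by these compounds, this single step cannot separate the contribution of the carbonyl from that of the isopropyl part, so it remains open how acetyl, benzoyl or a longer alkyl chain on the same nitrogen would read out. On these data alone, whether the same change would carry over to the core of compound 2 also remains open.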